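Swapping a benzyl ester for a cyanobutyl chain on two tetrazole cores

A few compounds are considered here, and "the series" means these few. Any claim that something is new, unique, unknown or untested is made for them only; others in the source may bear on it.

Compound 1 `COC(=O)C(c1ccccc1)n1nnnc1[C@@H](COCc1ccccc1)NC(=O)C(C)(C)N` and compound 3 `COC(=O)C(c1ccccc1)n1nnc([C@@H](COCc2ccccc2)NC(=O)C(C)(C)N)n1` are built from the same atoms joined differently; how the two cores differ is not broken down here. In a functional assay on H4 cells for agonist activity at growth hormone secretagogue receptor type 1 (Homo sapiens), read by FLIPR (a lower number here means that less compound is needed, a higher number that more compound is needed for the effect), compound 1 gives 20 nM, while compound 3 gives 3170 nM, the highest of the three measured numbers. Compound 2 `CC(C)(N)C(=O)N[C@H](COCc1ccccc1)c1nnnn1CCCCC#N` arises from compound 1 by the change (4-cyanobutyl in place of methoxycarbonyl)(benzyl on an aromatic nitrogen), and in this assay compound 2 gives 35 nM, so that a 1.8-fold higher number from compound 1 to compound 2 (0.24 log units; within the scatter). Compound 4 `CC(C)(N)C(=O)N[C@H](COCc1ccccc1)c1nnn(CCCCC#N)n1` arises from compound 3 by the same kind of change, (4-cyanobutyl in place of methoxycarbonyl)(benzyl on an aromatic nitrogen), although the place differs: in compound 1 the aromatic nitrogen is next to the ring nitrogen and next to the ring atom that bears a large group, whereas in compound 3 it is between two ring nitrogen atoms and two ring bonds from the ring atom that bears a large group. Because the step of a 1.8-fold higher number from compound 1 to compound 2 (0.24 log units; within the scatter) stayed within the scatter, compound 4 is expected to stay close to compound 3, with an estimated step of a 1.4-fold higher number from compound 3 to compound 4 (0.15 log units; within the scatter). Compound 4 is thus estimated at 4500 nM, between 1500 nM and 13000 nM.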

Compound 4, half-maximal effective concentration: 1860 nM
Beside the measured number, compound 4's estimate is 2.4-fold (0.38 log units) above it, within the range that was stated.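

In this assay, the change to 4-cyanobutyl on the second core gives a 1.7-fold lower number from compound 3 to compound 4 (0.23 log units; within the scatter), so on this core, as on the first, the change alone does not move the number beyond the scatter. Set side by side, however, the two steps do not match in direction or in size, and the gap between them is larger than the scatter allows: the same change on two cores in this assay, a 1.8-fold higher number (0.24 log units; within the scatter) from compound 1 to compound 2 and a 1.7-fold lower number (0.23 log units; within the scatter) from compound 3 to compound 4, 3.0-fold (0.47 log units) apart, beyond the scatter of two such steps This shows that the change is tolerated on both cores but that its exact effect does not carry over unchanged from one to the other, while two cores give no general rule and no reason for the gap.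

The compounds shown leave open whether a longer chain, or a chain ending in an amine or a carboxylic acid instead of the nitrile, would behave alike on both cores. They also leave open how 4-cyanobutyl would fare on any core beyond these two.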